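Mirror-Image Switch Tested for Cytotoxicity in Mouse Cells

The source may report more compounds than this note shows. Statements on the series, on what has been measured and on what is new or still open speak of the compounds shown alone.

Compound 2 `CC(C)(C)OC(=O)NCC(=O)N1CCC[C@H]1C(=O)N1[C@H](C(=O)O)[C@H]1C(=O)O` was run in a functional assay on J774 cells (Mus musculus) for cytotoxicity, with a stated time of 48 h (a lower number here means a stronger inhibitor, a higher number a weaker inhibitor), where compound 2 gives > 100000 nM, a limit of the assay rather than a number. Compound 1 `CC(C)(C)OC(=O)NCC(=O)N1CCC[C@@H](C(=O)N2[C@H](C(=O)OCc3ccccc3)[C@H]2C(=O)OCc2ccccc2)C1` likewise reaches only a limit, > 100000 nM. For compound 3 `CC(C)C[C@H](NC(=O)OC(C)(C)C)C(=O)N1CCC[C@H]1C(=O)N1[C@H](C(=O)O)[C@H]1C(=O)O` the result in this assay is "not determined" (no result reported). Compound 2 therefore stands where most of the known values sit, at the limit of > 100000 nM in this assay, at which 2 of the 3 values shown sit. The move to compound 4 `CC(C)(C)OC(=O)NCC(=O)N1CCC[C@@H]1C(=O)N1[C@H](C(=O)O)[C@H]1C(=O)O` alters no atom and no bond: the two compounds have the same atoms and bonds and differ only in configuration as drawn: 1 of 3 stereo elements differ; a stereocentre at a saturated ring carbon is drawn S in compound 2 and R in compound 4. Among the compounds with values here, no measured pair exists for comparison, and a limit offers no number to move away from, so no shift beyond the usual scatter is expected in this assay. Compound 4 is expected at 100000 nM, between 30000 nM and 300000 nM, an estimated step of a number no higher from compound 2 to compound 4 (the limit leaves the size open).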

Compound 4, half-maximal inhibitory concentration: > 100000 nM
Compound 4: a limit, no number; the forecaster's own chance of this, stated with the estimate: 85%; the middle value lies on the limit itself.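

Within the data shown here, compound 2 and compound 4 both stop at a limit of the assay, so no step between them can be read. The compounds shown leave open whether drawing that saturated ring carbon R rather than S changes cytotoxicity at all.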